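Methoxy for fluoro on the aryl ring of compound 3

This account rests on a few compounds, and the source may have more. Where it says the series, first, only, none or still open, it means among the compounds named here.

Measured compounds:
- compound 1, `COc1ccc(-c2cn3nc(Cl)sc3n2)cc1`: 38000 nM
- compound 2, `Clc1ccc(Cc2nn3cc(-c4ccccc4)nc3s2)cc1`: > 250000 nM
- compound 3, `Fc1ccc(-c2nc3sc(Cc4ccc(Cl)cc4)nn3c2Br)cc1`: > 250000 nM

Compound 3 stands at the edge of what a functional assay on L1210 cells (Mus musculus) for cytotoxicity, with a stated time of 48 h (a higher number here means a weaker inhibitor, a lower number a stronger inhibitor), reports: its value of > 250000 nM is a limit of the assay, not a number. Compound 2 likewise returns only a limit, > 250000 nM. Compound 1, on a different core, is the only one of the three with a measured number, 38000 nM, and it carries the same methoxyphenyl that enters below. The picture is summed up by the limit of > 250000 nM in this assay, at which 2 of the 3 values shown sit.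

Compound 4, `COc1ccc(-c2nc3sc(Cc4ccc(Cl)cc4)nn3c2Br)cc1`, differs from compound 3 by methoxy in place of fluoro on an aromatic carbon. Among the measured compounds shown here, no measured pair shows this change, so no size can be read off. Because compound 1 gives 38000 nM with the methoxyphenyl in place, a modest move toward a stronger inhibitor is expected. Still, compound 4 may well return only a limit again. Compound 4 is estimated at 150000 nM, within 30000 nM to 600000 nM, the expected step being an at least 1.6-fold lower number from compound 3 to compound 4 (0.22 log units; that floor lies within the scatter).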

Compound 4, half-maximal inhibitory concentration: 63000 nM
The estimate for compound 4 lay 2.4-fold (0.38 log units) above the measured number; the measured number falls inside the stated range.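

In this assay, among the compounds shown here, the change from 4-fluorophenyl to 4-methoxyphenyl on the shared core gives an at least 3.9-fold lower number from compound 3 to compound 4 (0.59 log units; beyond the scatter), the first step that can be read. Compound 4 returns a number and not a limit, so this position, para to a large group, does respond to a change of substituent. The size of the step remains only a lower bound, because the value of compound 3 is a limit and not a number: the limit of > 250000 nM in this assay, at which 2 of the 4 values shown sit.

As far as these compounds go, whether the step depends on the oxygen of the methoxy stays open; a hydroxyl, an amine or a longer chain such as ethoxy at this position would test that. Also open, from the compounds shown here alone, is whether the same change holds on a compound of this core without the bromo.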